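Aryl-to-alkyl swap at the fused core: permeability series

A few compounds are considered here, and "the series" means these few. Any claim that something is new, unique, unknown or untested is made for them only; others in the source may bear on it.

Measured compounds:
compound 1 `COc1cccc(CNCCCNc2ccnc3cc(-c4ccc(C(F)(F)F)cc4)ccc23)c1O`, 237 10^-6 cm/s
compound 2 `CCC(CC)c1ccc2c(NCCCNCc3cccc(OC)c3O)ccnc2c1`, 23 10^-6 cm/s
compound 3 `COc1cccc(CNCCCNc2ccnc3cc(-c4ccc(F)cc4)ccc23)c1O`, 237 10^-6 cm/s

All three were run in an ADME assay for permeability, using PAMPA, with a stated time of 30 min, at pH 7.4; on this read-out higher numbers stand for higher permeability and lower numbers for lower permeability. Compound 3 stands level with compound 1, the two together giving the highest numbers of the three, and the step of no change at the digits printed from compound 1 to compound 3 (within the scatter) is within the scatter. Compound 2 sits well apart: a 10-fold higher number from compound 2 to compound 3 (1.01 log units; beyond the scatter).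

Compound 4 `COc1cccc(CNCCCNc2ccnc3cc(CC4CCCCC4)ccc23)c1O` is not yet measured. Relative to compound 3 the change is cyclohexylmethyl in place of 4-fluorophenyl on an aromatic carbon.

Among the compounds with values here, the steps that bear on this are a 10-fold lower number from compound 1 to compound 2 (1.01 log units; beyond the scatter) and a 10-fold higher number from compound 2 to compound 3 (1.01 log units; beyond the scatter), both large, each trading a six-membered aromatic ring of carbon only for pentan-3-yl or back. Cyclohexylmethyl likewise brings a non-aromatic group in place of 4-fluorophenyl, so a step of similar size and downward direction is expected, a 5.9-fold lower number from compound 3 to compound 4 (0.77 log units; beyond the scatter). Compound 4 is estimated at 40 10^-6 cm/s, within a range of 15 10^-6 cm/s to 120 10^-6 cm/s.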

Compound 4, apparent permeability: 23 10^-6 cm/s
Beside the measured number, compound 4's estimate is 1.7-fold (0.24 log units) above it, within the range that was stated.
By their numbers in this assay, from the lowest: compounds 2 and 4 (each within the scatter of the next); then compounds 1 and 3 (each within the scatter of the next).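

At this aromatic carbon of the shared core, cyclohexylmethyl gives no change at the digits printed from compound 2 to compound 4 (within the scatter), so it sits with pentan-3-yl, while the aryl comparisons give a 10-fold lower number from compound 3 to compound 4 (1.01 log units; beyond the scatter) and a 10-fold lower number from compound 1 to compound 4 (1.01 log units; beyond the scatter). Among these four compounds, the numbers form two levels, and a non-aromatic carbon ring does not reach the level of compounds 1 and 3, which carry an aromatic ring of carbon only at this position. No available data give a cause for this split. Open, as far as these compounds go, is whether cyclohexyl attached directly, without the methylene link, stays at the lower level, and whether a pyridin-4-yl ring reaches the higher one.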